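Two Ring Stereocentres Flipped in a Naphthyl Sugar

The source may hold more compounds than are shown below. What is called first, only, known or untested is meant among the compounds shown, and "the series" means these compounds.

Compound 1, with the structure `O[C@H]1[C@H](Oc2ccc3ccccc3c2)OC[C@@H](O)[C@H]1O`, is a sugar-like ring carrying three hydroxyl groups and a naphthyl ether. In an ADME assay on CCD-1095SK cells (Homo sapiens) for antiproliferative activity, read by crystal violet staining, with a stated time of 96 h (a higher number here means that more compound is needed for the effect, a lower number that less compound is needed), compound 1 gives 182 uM. This is the higher of the two measured numbers. Going by the values given here, the other measured compound, compound 2, drawn as `O[C@@H]1CO[C@@H](Oc2ccc3ccccc3c2)C[C@H]1O`, gives 19 uM in this assay, a markedly lower number that lies beyond the usual scatter; the two structures differ in more than one way, so no single step between them is described here.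

Compound 3, drawn as `O[C@@H]1[C@@H](O)[C@H](Oc2ccc3ccccc3c2)OC[C@@H]1O`, is not yet measured. It relates to compound 1 as follows: the two compounds have the same atoms and bonds and differ only in configuration as drawn: 2 of 4 stereo elements differ; a stereocentre at a saturated ring carbon is drawn R in compound 1 and S in compound 3; a stereocentre at a saturated ring carbon is drawn R in compound 1 and S in compound 3. No other atom moves; only the way two hydroxyl-bearing ring carbons are arranged in space is changed.

Among the compounds with values here, with no measured pair showing the effect of such a change, the best guess is no step beyond the scatter. Compound 3 is therefore expected to give about 130 uM, in a range from 40 uM to 350 uM. The expected step of a 1.4-fold lower number from compound 1 to compound 3 (0.15 log units; within the scatter) is thus estimated to be small, with its direction uncertain.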

Compound 3, concentration for half-maximal effect: 48 uM
For compound 3 the middle estimate is 2.7-fold (0.43 log units) above the measured one; low and high end bracket the measured number.
By their numbers in this assay, from the lowest: compound 2; then compound 3; then compound 1.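

In this assay the spatial arrangement of two hydroxyl-bearing ring carbons is enough on its own to shift the result, with a 3.8-fold lower number from compound 1 to compound 3 (0.58 log units; beyond the scatter). The earlier comparison could not show this, as compound 1 and compound 2 differ in more than one way and their gap could not be tied to any single change. This new step can be assigned to stereochemistry alone, because no atom or bond separates the two compounds and only their three-dimensional arrangement changes: the fact that compounds 1 and 3 differ only in the configuration as drawn

The compounds shown do not separate the two flipped carbons, so it remains open whether one of them accounts for the step or both are needed, and the pair gives no reason at the level of the cells why this arrangement needs less compound. As far as these compounds go, it also remains open how the number would respond if an amine or a carboxylic acid took the place of a hydroxyl group at either of these carbons.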